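Methyl on the ring nitrogen: two cores compared

The source may report more compounds than this note shows. Statements on the series, on what has been measured and on what is new or still open speak of the compounds shown alone.

Compound 1 `c1ccc(Cc2nc3c(N4CCNCC4)cccc3[nH]2)cc1` gives 58 nM in an assay on HEK293 cells for displacement of a labelled ligand from 5-hydroxytryptamine receptor 6 (Homo sapiens), read by scintillation counting; on this read-out lower numbers stand for stronger inhibition and higher numbers for weaker inhibition. Compound 2 `CN1CCN(c2cccc3[nH]c(Cc4ccccc4)nc23)CC1` differs from it by methyl in place of hydrogen on an amine nitrogen in a ring and gives 66.8 nM in this assay; the step is a 1.2-fold higher number from compound 1 to compound 2 (0.06 log units; within the scatter). Compound 3 `c1ccc2c(Cc3nc4cc(N5CCNCC5)ccc4[nH]3)cccc2c1` rests on a different core, and how that core differs from the core of compound 1 is not broken down here. In this assay compound 3 gives only a limit, > 1000 nM. That value sits at the limit of > 1000 nM in this assay, at which 1 of the 3 values shown sits. Compound 4 `CN1CCN(c2ccc3[nH]c(Cc4cccc5ccccc45)nc3c2)CC1` differs from compound 3 by methyl in place of hydrogen on an amine nitrogen in a ring, the same change, at the same place, as from compound 1 to compound 2. The step that the limit leaves unreadable from compound 3 to compound 4 is expected to be equally small, because the same change gave a 1.2-fold higher number from compound 1 to compound 2 (0.06 log units; within the scatter). Compound 4 is therefore estimated at 1500 nM in this assay, somewhere between 600 nM and 5000 nM, and most probably again reported only as a limit.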

Compound 4, inhibition constant: > 1000 nM
Compound 4: only a limit was reported (the forecaster's own chance of this, stated with the estimate: 70%); the middle value does not contradict the limit.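

Compound 3 stands in this assay only as a limit, > 1000 nM. Compound 4 is also only a limit, > 1000 nM, so the step between these two compounds cannot be read. On these data alone, whether methyl in place of hydrogen changes the number on the core of compound 3 stays open.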